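The source may hold more compounds than are shown below. What is called first, only, known or untested is meant among the compounds shown, and "the series" means these compounds.

Of the compounds shown here, two have so far been measured in an assay on CHO cells for displacement of a labelled ligand from prostaglandin D2 receptor 2 (Homo sapiens), read by scintillation counting; on this read-out higher numbers stand for weaker inhibition and lower numbers for stronger inhibition. Compound 1 `O=C(O)COc1ccc(Cl)cc1C#Cc1cccc(CO)c1F` gives 41 nM. Compound 2 `Cc1ccc(S(=O)(=O)CCO)cc1C#Cc1cc(Cl)ccc1OCC(=O)O` gives 19 nM, the lowest of the two numbers; compound 1 stands at a higher number by a margin beyond the usual scatter of repeated measurements. Compound 3 `CCN(CC)S(=O)(=O)c1ccc(C)c(C#Cc2cc(Cl)ccc2OCC(=O)O)c1` has not been measured. Its structure departs from compound 2 in a single place: diethylamino in place of 2-hydroxyethyl on a sulfonyl sulfur. Among the compounds with values here, no measured pair carries this same change, so nothing in the data fixes its size or direction. Resting only on compound 2 as an anchor, a step of modest size is expected, and one no larger than the scatter is as plausible as any other; the estimated step from compound 2 to compound 3 is a 1.3-fold higher number from compound 2 to compound 3 (0.12 log units; within the scatter). Compound 3 is therefore expected to give about 25 nM in this assay, within a range from 8 nM to 80 nM.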

Compound 3, inhibition constant: 3.4 nM
For compound 3 the middle estimate is 7.4-fold (0.87 log units) above the measured one; measured number outside the range, below it.
By their numbers in this assay, from the lowest: compound 3; then compound 2; then compound 1.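

Putting diethylamino in place of 2-hydroxyethyl on the sulfonyl sulfur gives, in this assay, a 5.6-fold lower number from compound 2 to compound 3 (0.75 log units; beyond the scatter). The group on this sulfur therefore clearly affects the number, and in this pair the group that enters has no hydrogen-bond donor while the one that leaves has one, so a donor here is not needed for a low number. Which part of the change accounts for the step cannot be told, as nothing at hand bears on its cause.

Going by these compounds, it remains open whether the sulfonamide nitrogen or the two ethyl groups matter more, which dimethylamino or a plain ethyl on the same sulfur could help separate. How the number moves with dipropylamino or a morpholine ring at this place is also unknown.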